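The compounds below may be only part of what the source reports. "The series", "measured", "known", "first", "only" and "open" are said of these compounds alone.

Compound 3, `N#Cc1cccc(-c2nc(N)c3cc(Cc4ccccc4)sc3n2)c1`, sits second highest of the three numbers available in a functional assay on CHO-K1 cells for antagonist activity at adenosine receptor A1 (Homo sapiens), read by a beta-galactosidase reporter and cAMP accumulation, with stated times of 15 min and 6 h (a higher number here means a weaker inhibitor, a lower number a stronger inhibitor), where compound 3 gives 222 nM. Its nearest neighbour is compound 2, `Nc1nc(-c2cnco2)nc2sc(Cc3ccccc3)cc12`, which in this assay gives 106 nM; the furthest is compound 1, `Nc1nc(-c2ccc(C(F)F)o2)nc2sc(Cc3ccccc3)cc12`, which in this assay gives 3000 nM. The two swaps that led away from compound 1 were both large: a 28-fold lower number from compound 1 to compound 2 (1.45 log units; beyond the scatter) and a 14-fold lower number from compound 1 to compound 3 (1.13 log units; beyond the scatter). The step that bears most directly on what follows is the one between the two small aromatic replacements, a 2.1-fold higher number from compound 2 to compound 3 (0.32 log units; beyond the scatter), a modest change.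

Compound 4, `Nc1nc(-c2cnccn2)nc2sc(Cc3ccccc3)cc12`, differs from compound 3 in one place: pyrazin-2-yl in place of 3-cyanophenyl on an aromatic carbon. Among the compounds with values here, the group that enters is, like the one in compound 2, a small aromatic ring carrying ring nitrogen atoms, and the only comparison of this kind on record is a 2.1-fold higher number from compound 2 to compound 3 (0.32 log units; beyond the scatter), which was modest. Compound 1 shows that a different five-membered substituent at the same place can give a much weaker inhibitor, so the range kept for compound 4 is wide. The expected step is a 1.5-fold lower number from compound 3 to compound 4 (0.17 log units; within the scatter), a modest move toward a lower number, not far beyond the scatter. For compound 4 the estimate in this assay is 150 nM, with a range from 40 nM to 600 nM.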

Compound 4, inhibition constant: 91 nM
Beside the measured number, compound 4's estimate is 1.6-fold (0.22 log units) above it; the measured number falls inside the stated range.
By their numbers in this assay, from the lowest: compounds 4 and 2 (each within the scatter of the next); then compound 3; then compound 1.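

Exchanging 3-cyanophenyl for pyrazin-2-yl on the aromatic carbon between two ring nitrogen atoms gives a 2.4-fold lower number from compound 3 to compound 4 (0.39 log units; beyond the scatter) in this assay, so at this place a six-membered aromatic ring with two hetero atoms gives a lower number than the carbon-only ring bearing a nitrile. Set against the five-membered 1,3-oxazol-5-yl group, the change is a 1.2-fold lower number from compound 2 to compound 4 (0.07 log units; within the scatter), so in this assay the shown data do not separate these two rings, despite their different ring sizes. Within the data shown here, the remaining step, a 33-fold lower number from compound 1 to compound 4 (1.52 log units; beyond the scatter), is the largest seen at this position so far, and it leaves 5-(difluoromethyl)furan-2-yl alone at the high end of the four numbers, with every other group giving a number well below it.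

No measurement offered here accounts for any of these differences, so they stand as observations only. The compounds shown leave open whether an unsubstituted phenyl, a pyridine ring, an amine or a carboxylic acid at this position would give a number close to those of compound 2 and compound 4, and whether the furan ring itself or its difluoromethyl group goes with the high number of compound 1.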